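Sulfonyl substituent change in the acylsulfonamide series

A few compounds are considered here, and "the series" means these few. Any claim that something is new, unique, unknown or untested is made for them only; others in the source may bear on it.

Compound 1 `CC(C)NCCS(=O)(=O)NC(=O)c1ccc(Nc2nc(NC3(c4ccc(Cl)cc4)CC3)nc(OCC(F)(F)F)n2)cc1` is the reference of this set. Among the measured compounds shown here, in an ADME assay on microsomes from liver (Homo sapiens) for metabolic stability, with a stated time of 10 min (a lower number here means that less of the compound is left, a higher number that more of the compound is left), compound 1 gives 89%, the lowest of the three numbers measured so far, though its steps to both neighbours stay within the scatter. Compound 2 `CC(C)(C)NC(=O)NCCS(=O)(=O)NC(=O)c1ccc(Nc2nc(NC3(c4ccc(Cl)cc4)CC3)nc(OCC(F)(F)F)n2)cc1` gives 96% in this assay and compound 3 `CNC(=O)NCCS(=O)(=O)NC(=O)c1ccc(Nc2nc(NC3(c4ccc(Cl)cc4)CC3)nc(OCC(F)(F)F)n2)cc1` gives 97%. The measured steps are a number 7 percentage points higher from compound 1 to compound 2 (within the scatter), a number 8 percentage points higher from compound 1 to compound 3 (within the scatter) and a number 1 percentage points higher from compound 2 to compound 3 (within the scatter), all of them within the scatter.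

Compound 4 `Cc1ccccc1S(=O)(=O)NC(=O)c1ccc(Nc2nc(NC3(c4ccc(Cl)cc4)CC3)nc(OCC(F)(F)F)n2)cc1` is not yet measured in this assay. Its difference from compound 1 is 2-methylphenyl in place of 2-(isopropylamino)ethyl on a sulfonyl sulfur. For the measured compounds named here, the change sits on the sulfonyl sulfur, where none of the measured steps acted; those steps altered only the amine nitrogen at the end of the 2-(isopropylamino)ethyl chain, and each of them moved the number by no more than the scatter. They bear on the new step only in showing that this part of the shared core tolerated variation without a shift beyond the scatter. A step of that kind, or none beyond the scatter, is therefore expected, with wider uncertainty than for compounds 2 and 3.

Compound 4 is estimated at 85%, in the range 65% to 98%, corresponding to the expected step of a number 4 percentage points lower from compound 1 to compound 4 (within the scatter).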

Compound 4, percent of the compound remaining: 100%
Beside the measured number, compound 4's estimate is 15 percentage points below it, and the stated range ends below it.
By their numbers in this assay, from the lowest: compounds 1, 2, 3 and 4 (each within the scatter of the next, the first and the last beyond it).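

Among the compounds shown here, the sulfonyl sulfur is itself varied for the first time here, and in this assay putting 2-methylphenyl in place of 2-(isopropylamino)ethyl gives a number 11 percentage points higher from compound 1 to compound 4 (beyond the scatter) as the only step in this set that passes the scatter, though a modest one. Set against the two carbamoyl-capped chains, the same aromatic ring shows no such separation, with a number 3 percentage points higher from compound 3 to compound 4 (within the scatter) and a number 4 percentage points higher from compound 2 to compound 4 (within the scatter) both read as within the scatter, so only the chain ending in the isopropyl amine stands apart from compound 4 at this position. No measurement at hand accounts for the separation of compound 1 from compound 4.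

Still open, going by these compounds, is whether this step belongs to the aromatic ring or to the loss of the amine nitrogen, a question that an unsubstituted phenyl, a 4-methylphenyl or a plain methyl on the sulfonyl sulfur would help to separate. Equally open, on these data alone, is how a carboxylic acid or a longer chain in place of the 2-(isopropylamino)ethyl group would read in this assay on the same shared core.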